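Herbicidal triazines: a tert-butyl to isopropyl step

The source may hold more compounds than are shown below. What is called first, only, known or untested is meant among the compounds shown, and "the series" means these compounds.

Measured compounds:
compound 1, `CCCCNc1nc(Cl)nc(N[C@H](C)c2ccccc2)n1`, 38900 nM
compound 2, `CCCNc1nc(Cl)nc(N[C@H](C)c2ccccc2)n1`, 33100 nM
compound 3, `C[C@H](Nc1nc(Cl)nc(NC(C)(C)C)n1)c1ccccc1`, 7410 nM

In an ADME assay on the whole organism for inhibition, with Echinochloa crus-galli var. formosensis as the target, with a stated time of 4 days (on this read-out higher numbers stand for weaker inhibition and lower numbers for stronger inhibition), compound 3 gives the lowest number of the three; compound 2 and compound 1 both stand beyond the scatter from it. Compound 1 and compound 2 differ by hydrogen in place of methyl on a saturated chain carbon, three bonds along the chain from a nitrogen on an aromatic ring, and this gave a 1.2-fold lower number from compound 1 to compound 2 (0.07 log units; within the scatter). The difference between the core of compound 1 and the core of compound 3 is not broken down here.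

Compound 4, `CC(C)Nc1nc(Cl)nc(N[C@@H](C)c2ccccc2)n1`, is still to be measured in this assay. It differs from compound 3 by hydrogen in place of methyl on a saturated chain carbon bound to a nitrogen on an aromatic ring and two saturated chain carbons. For the measured compounds named here, this is the same kind of change as the one between compound 1 and compound 2, but the place differs: there the carbon lay three bonds along the chain from a nitrogen on an aromatic ring, here it is bound to a nitrogen on an aromatic ring and two saturated chain carbons.

Since compound 1 to compound 2 stayed within the scatter, a step of about a 1.2-fold higher number from compound 3 to compound 4 (0.08 log units; within the scatter) is expected for compound 4. The place is not the same, and the range is set wider on that account. Compound 4 is therefore estimated at 9000 nM, between 3000 nM and 30000 nM.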

Compound 4, half-maximal inhibitory concentration: 11000 nM
Beside the measured number, compound 4's estimate is 1.2-fold (0.09 log units) below it, and the stated range covers the measured number.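

In this assay, the change from tert-butyl to isopropyl gave a 1.5-fold higher number from compound 3 to compound 4 (0.17 log units; within the scatter), so removing this methyl left the number within the scatter. For the compounds shown here, that does not show that the change is silent on every core of the series: only two pairs bear on it, and the carbon that changes lies at a different place in each, three bonds along the chain from a nitrogen on an aromatic ring in one pair, and bound to a nitrogen on an aromatic ring and two saturated chain carbons in the other. Within those limits, the change carried over from one core to the other without a difference that can be told from the scatter: the same change on two cores in this assay, a 1.2-fold lower number (0.07 log units; within the scatter) from compound 1 to compound 2 and a 1.5-fold higher number (0.17 log units; within the scatter) from compound 3 to compound 4, 1.7-fold (0.24 log units) apart, within the scatter of two such steps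

The compounds shown leave open whether the same change would stay this small on a core carrying an amine or a methoxy group in place of the chlorine. They also leave open what a cyclopropyl group or a longer branched chain would do in place of the tert-butyl group.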